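A few compounds are considered here, and "the series" means these few. Any claim that something is new, unique, unknown or untested is made for them only; others in the source may bear on it.

Measured so far:
compound 1 `Cc1ccc(C(=O)NNC(=S)Nc2csc(-c3ccccc3)c2)cc1` — 30000 nM
compound 2 `Cc1ccc(C(=O)NNC(=S)Nc2csc(-c3ccc(C)cc3)c2)cc1` — 29000 nM
compound 3 `COc1cc(C(=O)NNC(=S)Nc2csc(-c3ccccc3)c2)cc(OC)c1OC` — 43000 nM

All three values come from a functional assay on MCF7 cells (Homo sapiens) for inhibition, read by colorimetric assay and MTT assay, with a stated time of 72 h; a lower number here means a stronger inhibitor, a higher number a weaker inhibitor. Compound 1 and compound 2 differ only by methyl in place of hydrogen on an aromatic carbon, and that change gave a 1.0-fold lower number from compound 1 to compound 2 (0.01 log units; within the scatter). Compound 3 carries a different core; the difference between the two cores is not broken down here, and its value in this assay sits within the scatter of both compound 1 and compound 2.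

Compound 4 `COc1cc(C(=O)NNC(=S)Nc2csc(-c3ccc(C)cc3)c2)cc(OC)c1OC` is not yet measured. It differs from compound 3 by methyl in place of hydrogen on an aromatic carbon, the same change as from compound 1 to compound 2. Because a 1.0-fold lower number from compound 1 to compound 2 (0.01 log units; within the scatter) lay within the scatter, the step to compound 4 is expected to be a 1.0-fold lower number from compound 3 to compound 4 (0.01 log units; within the scatter). On that basis compound 4 is estimated at 42000 nM in this assay, expected between 20000 nM and 90000 nM.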

Compound 4, half-maximal inhibitory concentration: 31000 nM
Compound 4: the middle estimate sits 1.4-fold (0.13 log units) above what was measured; the measured number falls inside the stated range.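

In this assay, methyl in place of hydrogen on an aromatic carbon gives a 1.4-fold lower number from compound 3 to compound 4 (0.14 log units; within the scatter). Set beside the earlier step, the same change on the two cores shows no difference that can be told apart: the same change on two cores in this assay, a 1.0-fold lower number (0.01 log units; within the scatter) from compound 1 to compound 2 and a 1.4-fold lower number (0.14 log units; within the scatter) from compound 3 to compound 4, 1.3-fold (0.13 log units) apart, within the scatter of two such steps. The change therefore carries from the core of compound 1 to the core of compound 3 as a step within the scatter on both, but this does not show that the methyl has any real effect of its own, or that a step beyond the scatter would carry over in the same way.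

The compounds shown leave open whether another group in place of that methyl, such as an amine or a carboxylic acid, would move the number beyond the scatter. On these data alone, whether the same holds on a third core also stays open.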